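Single stereocentre inversion from compound 1

This account rests on a few compounds, and the source may have more. Where it says the series, first, only, none or still open, it means among the compounds named here.

Two of the three results in this series are the limit of > 50000 nM in this assay, at which 2 of the 3 values shown sit. Compound 1 `CC(=O)O[C@@]1(C)CCC(=O)[C@@H](C)CCC[C@]2(C)O[C@H]2C(=O)C(=C(C)C)CC1` alone returns a number: in a functional assay on PC-3 cells (Homo sapiens) for cytotoxicity, read by MTT assay, with a stated time of 24 h (a lower number here means a stronger inhibitor, a higher number a weaker inhibitor), compound 1 gives 24300 nM. Compound 2 `CC(=O)O[C@@]1(C)CCC(=O)/C(C)=C/CC[C@]2(C)O[C@H]2C(=O)C(=C(C)C)CC1` reaches only the assay limit, and in this assay compound 2 gives > 50000 nM. Compound 3 `CC(=O)O[C@@]1(C)CCC/C(C)=C/CC[C@@]2(C)O[C@@H]2C(=O)C(=C(C)C)CC1` likewise returns a limit rather than a number; in this assay compound 3 gives > 50000 nM. Among the values shown, compound 1 is thus the only compound with a measurable figure.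

Compound 4 `CC(=O)O[C@@]1(C)CCC(=O)[C@H](C)CCC[C@]2(C)O[C@H]2C(=O)C(=C(C)C)CC1` is the unmeasured partner of compound 1. The change from compound 1 to compound 4 is the two compounds have the same atoms and bonds and differ only in configuration as drawn: 1 of 4 stereo elements differ; a stereocentre at a saturated ring carbon is drawn S in compound 1 and R in compound 4. Among the compounds with values here, no pair of measured compounds differs in one place, so no measured step gives the size of such a change, and the expectation rests on compound 1 alone. For compound 4 the step of a 1.2-fold higher number from compound 1 to compound 4 (0.09 log units; within the scatter) is expected to be small, within the scatter or slightly toward weaker inhibition in this assay. The estimate for compound 4 in this assay is 30000 nM, expected to fall between 10000 nM and 90000 nM.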

Compound 4, half-maximal inhibitory concentration: 44900 nM
For compound 4 the middle estimate is 1.5-fold (0.18 log units) below the measured one; the range from low to high includes it.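

In this assay, within the data shown here, the switch from S to R at the saturated ring carbon gives a 1.8-fold higher number from compound 1 to compound 4 (0.27 log units; within the scatter), the first measured step. Compound 4 also returns a number, 44900 nM, so this position gives a readable value in either configuration, and the two configurations cannot be told apart beyond the scatter. The step speaks to configuration alone, because nothing else separates the pair: the fact that compounds 1 and 4 differ only in the configuration as drawn.

Steps to compounds 2 and 3 cannot be read, as each of them stands at a limit of the assay rather than at a number: the limit of > 50000 nM in this assay, at which 2 of the 4 values shown sit. Going by these compounds, what an amine or a carboxylic acid at this saturated ring carbon would give in this assay stays open.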